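A few compounds are considered here, and "the series" means these few. Any claim that something is new, unique, unknown or untested is made for them only; others in the source may bear on it.

Compound 1 `COc1ccc(-c2cn3ccnc3c(-c3ccc4ncn(C5CCCCC5)c4c3)n2)cc1` has the highest number of the three measured compounds in a functional assay on SR cells (Homo sapiens) for inhibition, read by sulforhodamine B assay, with a stated time of 48 h, tested at 10 uM (a lower number here means less inhibition, a higher number more inhibition at the concentration tested (going by the name of the read-out)), where compound 1 gives 91.7%. Compound 2 `c1cn2cc(-c3ccsc3)nc(-c3ccc4ncn(C5CCCCC5)c4c3)c2n1` gives 14.3%, and compound 3 `CC(=O)c1ccc(-c2cn3ccnc3c(-c3ccc4ncn(C5CCCCC5)c4c3)n2)cc1` gives 23.6%. Both of the following steps lie beyond the scatter: a number 77.4 percentage points lower from compound 1 to compound 2 (beyond the scatter) and a number 68.1 percentage points lower from compound 1 to compound 3 (beyond the scatter). The step between the two compounds with the lower numbers, a number 9.3 percentage points higher from compound 2 to compound 3 (within the scatter), stays within the scatter.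

Compound 4 `c1csc(-c2cn3ccnc3c(-c3ccc4ncn(C5CCCCC5)c4c3)n2)c1` has not yet been measured. It differs from compound 1 in one place: thiophen-2-yl in place of 4-methoxyphenyl on an aromatic carbon. The closest guide is the exchange of 4-methoxyphenyl for thiophen-3-yl, which produced a number 77.4 percentage points lower from compound 1 to compound 2 (beyond the scatter), a large loss beyond the scatter. Removing the methoxy in favour of acetyl, seen in a number 68.1 percentage points lower from compound 1 to compound 3 (beyond the scatter), was also a large loss. Thiophen-2-yl is likewise a five-membered aromatic ring with one hetero atom, so a loss of similar size is expected, and compound 4 is expected to show a number 71.7 percentage points lower from compound 1 to compound 4 (beyond the scatter). Compound 4 is therefore estimated at 20%, with a range from 5% to 45%.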

Compound 4, a percentage reported as inhibition, at one concentration (the size of the read-out at that concentration, not a potency): 27.2%
For compound 4 the middle estimate is 7.2 percentage points below the measured one; low and high end bracket the measured number.
By their numbers in this assay, from the lowest: compounds 2, 3 and 4 (each within the scatter of the next, the first and the last beyond it); then compound 1.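

The attachment point of the thiophene ring matters in this assay: joining the same ring through a different carbon gives a number 12.9 percentage points higher from compound 2 to compound 4 (beyond the scatter), a modest step. A second thiophene also fails to keep the activity of the 4-methoxyphenyl group, with a number 64.5 percentage points lower from compound 1 to compound 4 (beyond the scatter), while a number 3.6 percentage points higher from compound 3 to compound 4 (within the scatter) lies within the scatter, so thiophen-2-yl and 4-acetylphenyl cannot be told apart here. No measurement is available to explain either the large loss or the modest difference between the two thiophenes.

On these data alone, it remains open whether the high number of compound 1 depends on the methoxy group itself, or whether a plain phenyl ring or a phenyl ring carrying a hydroxyl, an amine or an ethoxy group in its place would also keep it. Because each compound was read at one concentration, these numbers also leave their potencies open.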